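The source may report more compounds than this note shows. Statements on the series, on what has been measured and on what is new or still open speak of the compounds shown alone.

In a functional assay on K562 cells (Homo sapiens) for inhibition, with a stated time of 72 h (on this read-out higher numbers stand for weaker inhibition and lower numbers for stronger inhibition), three compounds with a shared core have been measured: compound 1 (`NC1CCC(Nc2nc(NCc3ccc(-c4ccco4)cc3)c3ncn(C4CCCC4)c3n2)CC1`) gives 96 nM, compound 2 (`NC1CCC(Nc2nc(NCc3ccc(-c4ccsc4)cc3)c3ncn(C4CCCC4)c3n2)CC1`) gives 150 nM, and compound 3 (`NC1CCC(Nc2nc(NCc3ccc(-c4ccco4)nc3)c3ncn(C4CCCC4)c3n2)CC1`) gives 67 nM. Compound 3 sits at the low end of these numbers, but it shares that end, as the data show a 1.4-fold lower number from compound 1 to compound 3 (0.16 log units; within the scatter). Its other gap is modest: a 2.2-fold lower number from compound 2 to compound 3 (0.35 log units; beyond the scatter).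

Compound 4 (`Nc1ccccc1CNc1nc(NC2CCC(N)CC2)nc2c1ncn2C1CCCC1`) brings a larger change: 2-aminophenyl in place of 6-(furan-2-yl)pyridin-3-yl on a saturated chain carbon bound to a nitrogen on an aromatic ring. The measured steps, including a 1.6-fold higher number from compound 1 to compound 2 (0.19 log units; within the scatter), only exchange one ring group for a similar one, and none removes a ring, so they offer limited guidance here. The expected result is a 5.2-fold higher number from compound 3 to compound 4 (0.72 log units; beyond the scatter), a weakening beyond the scatter. Compound 4 is estimated at 350 nM, with an expected range of 90 nM to 1500 nM.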

Compound 4, half-maximal inhibitory concentration: 4040 nM
Estimate against measurement, compound 4: 12-fold (1.06 log units) below; measured number above the stated range.
By their numbers in this assay, from the lowest: compounds 3, 1 and 2 (each within the scatter of the next, the first and the last beyond it); then compound 4.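

Among the earlier compounds, exchanging one two-ring group for another at this position changed the number only slightly or modestly. The smaller, single-ring 2-aminophenyl has a far larger effect (a 60-fold higher number from compound 3 to compound 4 (1.78 log units; beyond the scatter); a 27-fold higher number from compound 2 to compound 4 (1.43 log units; beyond the scatter); a 42-fold higher number from compound 1 to compound 4 (1.62 log units; beyond the scatter)), so this position does not accept every aromatic group equally. No measurement available here explains this loss. 

Compound 4 both loses the second ring and gains the amine, so the compounds shown cannot separate these two changes. A plain phenyl group would be needed to tell them apart.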